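The source may report more compounds than this note shows. Statements on the series, on what has been measured and on what is new or still open speak of the compounds shown alone.

Measured so far in a functional assay for inhibition, with Homo sapiens as the target; a lower number here means a stronger inhibitor, a higher number a weaker inhibitor:
compound 1, `CC1CCN(c2cccc(Nc3nccc(-c4cccnc4)n3)c2)CC1`: 1200 nM
compound 2, `CN(C)c1cccc(Nc2nccc(-c3cccnc3)n2)c1`: 1800 nM
compound 3, `CC(=O)Nc1cccc(Nc2nccc(-c3ccncc3)n2)c1`: 2700 nM

Compound 3 gives the highest of the three numbers. Its nearest neighbour is compound 2, and those two values lie within the scatter of each other; the gap from compound 3 to compound 1 lies beyond the scatter. Going by the values given here, the single resolved step in the set, a 1.5-fold higher number from compound 1 to compound 2 (0.18 log units; within the scatter), concerns a different position and does not bear on the change considered here.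

Compound 4, `CC(=O)Nc1cccc(Nc2nccc(-c3cccnc3)n2)c1`, differs from compound 3 in one place: pyridin-3-yl in place of pyridin-4-yl on an aromatic carbon. Among the compounds with values here, no measured pair isolates this change. Compounds 1 and 2 both carry pyridin-3-yl and give lower numbers than compound 3, but each also differs from compound 3 elsewhere, so that comparison is not clean. The expectation is therefore a small step, with no firm direction beyond the scatter. Compound 4 is expected at 2000 nM with a range from 700 nM to 6000 nM. This corresponds to an expected step of a 1.4-fold lower number from compound 3 to compound 4 (0.13 log units; within the scatter).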

Compound 4, half-maximal inhibitory concentration: 3600 nM
Compound 4: middle estimate off by 1.8-fold (0.26 log units), on the low side; low and high end bracket the measured number.
By their numbers in this assay, from the lowest: compounds 1, 2, 3 and 4 (each within the scatter of the next, the first and the last beyond it).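

In this assay, pyridin-3-yl in place of pyridin-4-yl on the aromatic carbon now has a clean pair, and the two ring isomers are not separated with acetamido held fixed (a 1.3-fold higher number from compound 3 to compound 4 (0.12 log units; within the scatter)). Going by these compounds alone, with pyridin-3-yl held fixed, the other substituent can also be read for the first time: acetamido in place of dimethylamino stays within the scatter (a 2.0-fold higher number from compound 2 to compound 4 (0.30 log units; within the scatter)), while acetamido in place of 4-methylpiperidin-1-yl gives the only step here beyond it, and a modest one (a 3.0-fold higher number from compound 1 to compound 4 (0.48 log units; beyond the scatter)). No measurement on hand offers an account of these steps.

On these data alone, whether the pyridine isomers also stay unseparated with dimethylamino or 4-methylpiperidin-1-yl in place of acetamido remains open. So does the reading for pyridin-2-yl or plain phenyl on that carbon, and for a morpholine or a carboxylic acid in place of acetamido.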